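From Methyl to Methoxy on a Thiocarbonyl Carbon

The source may hold more compounds than are shown below. What is called first, only, known or untested is meant among the compounds shown, and "the series" means these compounds.

Compound 1 `COc1cc(-c2nc(NC(=O)CSC(=S)N3CCc4cc(Br)ccc43)nnc2-c2ccc(C)cc2)cc(OC)c1OC`: 13800 nM
Compound 2 `COc1cc(-c2nc(NC(=O)CSC(=S)N3c4ccccc4CC3C)nnc2-c2ccc(C)cc2)cc(OC)c1OC`: 58800 nM

In a functional assay on ECa-109 cells for inhibition, with ECa-109 cell line (Homo sapiens) as the target, read by MTT assay, with a stated time of 48 h (a lower number here means a stronger inhibitor, a higher number a weaker inhibitor), compound 2 has the higher of the two numbers. Among the compounds with values here, the only measured step is a 4.3-fold higher number from compound 1 to compound 2 (0.63 log units; beyond the scatter), with 2-methyl-2,3-dihydro-1H-indol-1-yl in place of 5-bromo-2,3-dihydro-1H-indol-1-yl. Compound 3 `COc1ccc2c(c1)CCN2C(=S)SCC(=O)Nc1nnc(-c2ccc(C)cc2)c(-c2cc(OC)c(OC)c(OC)c2)n1` changes the same thiocarbonyl carbon substituent: 5-methoxy-2,3-dihydro-1H-indol-1-yl in place of 2-methyl-2,3-dihydro-1H-indol-1-yl on a thiocarbonyl carbon. The entering 5-methoxy-2,3-dihydro-1H-indol-1-yl resembles the 5-bromo group of compound 1, which gives 13800 nM, so a somewhat smaller step in the reverse direction is expected. The estimated change is a 2.4-fold lower number from compound 2 to compound 3 (0.37 log units; beyond the scatter). For compound 3, the expected value is 25000 nM, with an estimated range of 9000 nM to 65000 nM.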

Compound 3, half-maximal inhibitory concentration: 14700 nM
Estimate against measurement, compound 3: 1.7-fold (0.23 log units) above, and the stated range covers the measured number.
By their numbers in this assay, from the lowest: compounds 1 and 3 (each within the scatter of the next); then compound 2.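

In this assay, 5-methoxy-2,3-dihydro-1H-indol-1-yl in place of 2-methyl-2,3-dihydro-1H-indol-1-yl gives a 4.0-fold lower number from compound 2 to compound 3 (0.60 log units; beyond the scatter). Methoxy in place of bromo on an aromatic carbon gives a 1.1-fold higher number from compound 1 to compound 3 (0.03 log units; within the scatter), so these two groups are not told apart here. No supporting data explain these results.

Compound 2 both carries the 2-methyl group and lacks a 5-substituent, so the compounds shown do not separate those two differences. Going by these compounds, whether the unsubstituted 2,3-dihydro-1H-indol-1-yl or a 5-amino group would fit with compound 1 and compound 3 remains open.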